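The compounds below may be only part of what the source reports. "The series", "measured", "known", "first", "only" and "open" are said of these compounds alone.

In a functional assay on CCRF-CEM cells (Homo sapiens) for inhibition, read by MTT assay, with a stated time of 4 days (a lower number here means a stronger inhibitor, a higher number a weaker inhibitor), compound 1 (`COc1cc(NC(C)CCCNC(=O)NN)c2ncccc2c1`) gives > 250000 nM as a limit of the assay and not as a number. Compound 2 (`O=C(NC(c1ccccc1)c1ccc(Cl)cc1)n1nnc2ccccc21`) gives 116000 nM there, and compound 3 (`O=C1NCCN1C(c1ccccc1)(c1ccccc1)c1ccccc1`) gives 27000 nM there, both on other cores. Compound 4 (`COc1cc(NC(C)CCCNC(=O)Nc2ccc(Cl)c(C(F)(F)F)c2)c2ncccc2c1`) keeps the core of compound 1 and takes 4-chloro-3-(trifluoromethyl)phenyl in place of amino on an amide-type nitrogen. Among the compounds with values here, no measured pair shows this change, so its size remains a matter of judgement. A large step toward stronger inhibition in this assay is expected, estimated as an at least 16-fold lower number from compound 1 to compound 4 (1.22 log units; beyond the scatter) and lying beyond the scatter. For compound 4 the estimated value is 15000 nM with an expected range from 4000 nM to 50000 nM on repeated measurement.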

Compound 4, half-maximal inhibitory concentration: 3100 nM
Compound 4: middle estimate off by 4.8-fold (0.68 log units), on the high side; measured number below the stated range.
By their numbers in this assay, from the lowest: compound 4; then compound 3; then compound 2. At a limit, above all of these: compound 1.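

At the amide-type nitrogen whose other neighbour is the carbonyl carbon, 4-chloro-3-(trifluoromethyl)phenyl in place of amino gives, in this assay, an at least 80-fold lower number from compound 1 to compound 4 (1.90 log units; beyond the scatter). With this group the core of compound 1 reaches a measured number, as compound 4 gives 3100 nM in this assay. Compound 1 stands at a limit, so the step is only a bound: the limit of > 250000 nM in this assay, at which 1 of the 4 values shown sits.

The compounds shown leave open whether a plain phenyl, without the chlorine and the trifluoromethyl, would give a similar step. They also leave open what a short alkyl chain such as ethyl would give at this nitrogen.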